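The source may report more compounds than this note shows. Statements on the series, on what has been measured and on what is new or still open speak of the compounds shown alone.

Measured so far:
Compound 1 `CN1CCN(c2ccc(Nc3ncc4c(=O)c(-c5c(Cl)cccc5Cl)cn(C)c4n3)cc2)CC1` — 270 mL/min/kg
Compound 2 `CN1CCN(c2ccc(Nc3ncc4c(=O)c(-c5c(Cl)cccc5Cl)cn(C5COC5)c4n3)cc2)CC1` — 582 mL/min/kg

In an ADME assay on microsomes (Mus musculus) for pharmacokinetics (on this read-out lower numbers stand for slow clearance and higher numbers for fast clearance), compound 1 gives 270 mL/min/kg and compound 2 gives 582 mL/min/kg. Among the compounds with values here, compound 2 therefore stands at the higher of the two numbers, and the single measured step, a 2.2-fold higher number from compound 1 to compound 2 (0.33 log units; beyond the scatter), lies beyond the usual scatter. That step came from a change on the aromatic nitrogen of the shared core, where oxetan-3-yl took the place of methyl.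

Compound 3 `CN(C)CCn1cc(-c2c(Cl)cccc2Cl)c(=O)c2cnc(Nc3ccc(N4CCN(C)CC4)cc3)nc21` has not yet been measured in this assay. It differs from compound 2 in one place: 2-(dimethylamino)ethyl in place of oxetan-3-yl on an aromatic nitrogen. Within the data shown here, no measured step covers this exact exchange. Among the measured compounds shown here, the only step available shows that swapping the group on that nitrogen can move the clearance number by a modest amount beyond the scatter, but it gives no direction for the present swap. The expected step, a 1.4-fold lower number from compound 2 to compound 3 (0.14 log units; within the scatter), is therefore small and uncertain, with a wide range on both sides. Compound 3 is estimated at 420 mL/min/kg, between 180 mL/min/kg and 1000 mL/min/kg.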

Compound 3, clearance: 1970 mL/min/kg
Compound 3: middle estimate off by 4.7-fold (0.67 log units), on the low side, and the stated range ends below it.
By their numbers in this assay, from the lowest: compound 1; then compound 2; then compound 3.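

In this assay, within the data shown here, the group on this aromatic nitrogen proves able to move the clearance number much further than the single earlier step suggested: putting 2-(dimethylamino)ethyl in place of oxetan-3-yl gives a 3.4-fold higher number from compound 2 to compound 3 (0.53 log units; beyond the scatter) while the rest of the molecule stays the same, and measuring the same chain against methyl gives a 7.3-fold higher number from compound 1 to compound 3 (0.86 log units; beyond the scatter) as the widest gap in the set. With all three compounds differing only at this one place, the order runs from methyl at the low end, through oxetan-3-yl, to 2-(dimethylamino)ethyl at the high end, so neither replacement of methyl gives a lower number here. No supporting measurement is available to say what lies behind the rise seen with this chain.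

Three groups cannot separate the effect of the amine nitrogen in the chain from that of the chain itself, and a plain all-carbon chain such as n-butyl on the same nitrogen would be the direct comparison. On these data alone, it also stays open how a longer chain ending in the same dimethylamine, or a morpholine at the end of the chain, would fall in this order.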